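Amide aryl variation and cytotoxicity on a shared core

A few compounds are considered here, and "the series" means these few. Any claim that something is new, unique, unknown or untested is made for them only; others in the source may bear on it.

Measured compounds:
- Compound 1, `CC(C)(C)C(=O)N(CCCCCCN1C[C@H](O)[C@@H](O)[C@H](O)[C@H]1CO)C1CCCCC1`: in an ADME assay on MDBK cells (Bos taurus) for cytotoxicity, read by MTT assay (on this read-out higher numbers stand for lower toxicity in this test and lower numbers for higher toxicity in this test), compound 1 gives > 500000 nM, a limit of the assay rather than a number.
- Compound 2, `O=C(c1ccccc1)N(CCCCCCN1C[C@H](O)[C@@H](O)[C@H](O)[C@H]1CO)C1CCCCC1`: in this assay compound 2 gives > 500000 nM, again a limit of the assay.

Compound 2 therefore stands at the limit of > 500000 nM in this assay, at which 2 of the 2 values shown sit, and no ordering within the pair can be read. Going by the values given here, the only step with two measured ends is a step that the two limits leave unreadable from compound 1 to compound 2, which is unreadable since both ends are limits. Compound 3, `O=C(c1cc(F)c(F)cc1F)N(CCCCCCN1C[C@H](O)[C@@H](O)[C@H](O)[C@H]1CO)C1CCCCC1`, arises from compound 2 by 2,4,5-trifluorophenyl in place of phenyl on a carbonyl carbon. Among the compounds with values here, no measured step bears on this change with a readable size, so the expectation rests only on both measured compounds sitting at the limit. Compound 3 is expected to give 500000 nM in this assay, with a range of 200000 nM to 1500000 nM. The step that this estimate means, a number no higher from compound 2 to compound 3 (the limit leaves the size open), is expected to be none beyond the scatter, and most likely compound 3 will also return only a limit.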

Compound 3, half-maximal cytotoxic concentration: > 500000 nM
Compound 3: no number, only a limit; the forecaster's own chance of this, stated with the estimate: 80%; the middle value lies on the limit itself.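

In this assay compound 3 gives > 500000 nM, a limit of the assay. No step among compound 1, compound 2 and compound 3 can be read, because all three stand at a limit: the limit of > 500000 nM in this assay, at which 3 of the 3 values shown sit.

Going by these compounds, whether the tert-butyl, phenyl and 2,4,5-trifluorophenyl compounds differ in cytotoxicity at all remains open.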